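From Methyl to 2-Oxopiperidin-4-yl on an Amide Nitrogen

The source may report more compounds than this note shows. Statements on the series, on what has been measured and on what is new or still open speak of the compounds shown alone.

In a physicochemical assay for solubility, read by spectrophotometry, measured as kinetic solubility, at pH 8, tested at 500 uM (a lower number here means a less soluble compound, a higher number a more soluble compound), compound 1 `Cn1ccc2ccc(-c3cc(Nc4ccccc4S(N)(=O)=O)cc4nccnc34)cc21` gives 6 ug/mL and compound 2 `Cn1ccc2ccc(-c3cc(Nc4ccccc4S(=O)(=O)Nc4cncnc4)cc4nccnc34)cc21` gives 254 ug/mL on the same scale. Compound 3 `CNC(=O)c1ccncc1Nc1cc(-c2ccc3ccn(C)c3c2)c2nccnc2c1` reads 4 ug/mL there, close to compound 1 and far from compound 2. The measured step between the first and third of these is a 1.5-fold lower number from compound 1 to compound 3 (0.18 log units; within the scatter) and so shows no real separation.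

The change to compound 4 `Cn1ccc2ccc(-c3cc(Nc4cnccc4C(=O)NC4CCNC(=O)C4)cc4nccnc34)cc21` is 2-oxopiperidin-4-yl in place of methyl on an amide-type nitrogen on an otherwise unchanged structure. Among the compounds with values here, no measured step makes this same change. The closest is a 42-fold higher number from compound 1 to compound 2 (1.63 log units; beyond the scatter) and there a ring-bearing group also replaced a smaller substituent on a nitrogen, though pyrimidin-5-yl entered in place of hydrogen on a sulfonamide nitrogen, which is a different setting. That single precedent supports only a cautious expectation of a rise. In this assay the expected move is a 5.0-fold higher number from compound 3 to compound 4 (0.70 log units; beyond the scatter) and it should remain well short of that large step. Compound 4 is estimated at 20 ug/mL within a range of 5 ug/mL to 120 ug/mL on this read-out.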

Compound 4, solubility: 242 ug/mL
The estimate for compound 4 lay 12-fold (1.08 log units) below the measured number; the measured number lies above the stated range.
By their numbers in this assay, from the lowest: compounds 3 and 1 (each within the scatter of the next); then compounds 4 and 2 (each within the scatter of the next).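

In this assay the amide-type nitrogen proves a place where a single substituent change moves the number strongly: 2-oxopiperidin-4-yl in place of methyl gives a 61-fold higher number from compound 3 to compound 4 (1.78 log units; beyond the scatter) on an otherwise unchanged structure. Before this, the only large step stood on a sulfonamide nitrogen, as a 42-fold higher number from compound 1 to compound 2 (1.63 log units; beyond the scatter) with pyrimidin-5-yl in place of hydrogen, so a large step is now seen on two different nitrogen settings with two different groups. Nothing measured here explains the size of this rise.

As far as these compounds go, whether the step depends on the ring, its carbonyl or its ring nitrogen stays open, since one group cannot separate these parts. From the compounds shown here alone, how a cyclohexyl group, a piperidin-4-yl amine or a short open chain such as hydroxyethyl would read on the same amide-type nitrogen also remains unknown.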